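A Ring Swap Repeated on a Second Core

A few compounds are considered here, and "the series" means these few. Any claim that something is new, unique, unknown or untested is made for them only; others in the source may bear on it.

The three measured compounds and their solubility in a physicochemical assay for solubility, read by HPLC, in phosphate buffer, measured as kinetic solubility, at pH 7.4; a lower number here means a less soluble compound, a higher number a more soluble compound:
compound 1, `CCC(=O)c1cc(-c2ccc(OC)cc2)n(-c2ccc(S(N)(=O)=O)cc2)c1C`, gives 12800 nM;
compound 2, `CCC(=O)c1cc(-c2cccc(Cl)c2)n(-c2ccc(S(N)(=O)=O)cc2)c1C`, gives 12600 nM;
compound 3, `CCOC(=O)c1cc(-c2ccc(OC)cc2)n(-c2ccc(S(N)(=O)=O)cc2)c1C`, gives 16100 nM.

Compound 1 and compound 2 differ by one change, (3-chlorophenyl in place of 4-methoxyphenyl on an aromatic carbon), and that change made the step of a 1.0-fold lower number from compound 1 to compound 2 (0.01 log units; within the scatter). Compound 3 differs from compound 1 in its core by ethoxy in place of ethyl on a carbonyl carbon, with the step of a 1.3-fold higher number from compound 1 to compound 3 (0.10 log units; within the scatter). Among the three, compound 3 stands highest, but its gap to compound 1 and its gap to compound 2 both lie within the scatter, so no order among them can be claimed.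

Compound 4, `CCOC(=O)c1cc(-c2cccc(Cl)c2)n(-c2ccc(S(N)(=O)=O)cc2)c1C`, has not yet been measured in this assay. It differs from compound 3 by 3-chlorophenyl in place of 4-methoxyphenyl on an aromatic carbon. Among the compounds with values here, this is the same kind of change as the one from compound 1 to compound 2, not the same change: around the place, the ring atom two ring bonds away bears an ethoxycarbonyl group in compound 3 where it bears a propanoyl group in compound 1.

For compound 4 a step of a 1.0-fold lower number from compound 3 to compound 4 (0.01 log units; within the scatter) is expected in this assay, beside the earlier one. This expectation rests on the step of a 1.0-fold lower number from compound 1 to compound 2 (0.01 log units; within the scatter), which lay within the scatter, and on the value of compound 3, 16100 nM, as the starting point. Compound 4 is therefore estimated at 15800 nM, with a range from 8000 nM to 32000 nM.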

Compound 4, solubility: 9200 nM
For compound 4 the middle estimate is 1.7-fold (0.23 log units) above the measured one; the range from low to high includes it.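

Carried onto the core of compound 3, the swap of 4-methoxyphenyl for 3-chlorophenyl gave in this assay a step of a 1.8-fold lower number from compound 3 to compound 4 (0.24 log units; within the scatter) and, on the core of compound 1, a step of a 1.0-fold lower number from compound 1 to compound 2 (0.01 log units; within the scatter), so on both cores the swap stays within the scatter. Within the data shown here, the other single change, ethoxy in place of ethyl on the carbonyl carbon, likewise gave a 1.4-fold lower number from compound 2 to compound 4 (0.14 log units; within the scatter) with the 3-chlorophenyl ring and a 1.3-fold higher number from compound 1 to compound 3 (0.10 log units; within the scatter) with the 4-methoxyphenyl ring, and so this small square of compounds holds no step that stands clear of repeat measurement. This shows that no effect of the ring swap could be told apart from the scatter on either core, but it does not show that the swap has no effect or that it would behave alike on any other core, and nothing given here bears on the size of these steps.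

The compounds shown leave open how the same swap would read with a carboxylic acid or a longer alkyl chain on the carbonyl carbon. They also leave open what an aminomethyl group on the aromatic ring, or a pyridine ring in place of 3-chlorophenyl, would do in this assay.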